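Swapping Chlorines for Fluorines on a Benzimidazole Group

A few compounds are considered here, and "the series" means these few. Any claim that something is new, unique, unknown or untested is made for them only; others in the source may bear on it.

Compound 2 `CN1CCN(CCCN(c2nc3cc(Cl)c(Cl)cc3[nH]2)[C@@H]2CC[C@]3(c4cccc(C#N)c4)C[C@@H]3C2)CC1` carries a 5,6-dichloro-1H-benzimidazol-2-yl group, and in an assay on isolated protein for binding affinity to melanin-concentrating hormone receptor 1 (Homo sapiens) (on this read-out higher numbers stand for weaker inhibition and lower numbers for stronger inhibition), compound 2 gives 2.2 nM. Compound 1 `CN1CCN(CCCN(c2nc3cc(F)c(F)cc3[nH]2)[C@@H]2CC[C@]3(c4cccc(C#N)c4)C[C@@H]3C2)CC1` differs from it in one place, (5,6-difluoro-1H-benzimidazol-2-yl in place of 5,6-dichloro-1H-benzimidazol-2-yl on an amine nitrogen), and in this assay compound 1 gives 8.4 nM; the change made a 3.8-fold higher number from compound 2 to compound 1 (0.58 log units; beyond the scatter). Compound 3 `CN1CCN(CCCN(c2nc3cc(Cl)c(Cl)cc3[nH]2)[C@@H]2CC[C@]3(c4cccc(C#N)c4)C[C@H]23)CC1` keeps the dichloro group but has a different core; the difference between the two cores is not broken down here. In this assay compound 3 gives 6.8 nM. Compound 4 `CN1CCN(CCCN(c2nc3cc(F)c(F)cc3[nH]2)[C@@H]2CC[C@]3(c4cccc(C#N)c4)C[C@H]23)CC1` arises from compound 3 by the same change, (5,6-difluoro-1H-benzimidazol-2-yl in place of 5,6-dichloro-1H-benzimidazol-2-yl on an amine nitrogen), at the same place. Because the earlier change made a 3.8-fold higher number from compound 2 to compound 1 (0.58 log units; beyond the scatter), a step of similar size is expected here, a 3.8-fold higher number from compound 3 to compound 4 (0.58 log units; beyond the scatter). Compound 4 is therefore expected to give about 26 nM, most likely between 10 nM and 65 nM.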

Compound 4, inhibition constant: 20.7 nM
The estimate for compound 4 lay 1.3-fold (0.10 log units) above the measured number, and the stated range covers the measured number.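

In this assay, putting 5,6-difluoro-1H-benzimidazol-2-yl in place of 5,6-dichloro-1H-benzimidazol-2-yl gave a 3.0-fold higher number from compound 3 to compound 4 (0.48 log units; beyond the scatter), so the number rose on this core too. Set beside the earlier step, the two agree in direction and in size: the same change on two cores in this assay, a 3.8-fold higher number (0.58 log units; beyond the scatter) from compound 2 to compound 1 and a 3.0-fold higher number (0.48 log units; beyond the scatter) from compound 3 to compound 4, 1.3-fold (0.10 log units) apart, within the scatter of two such steps. This shows that, in these two pairs, the change carried from one core to the other with much the same effect, but two pairs cannot establish a rule for the series, and the numbers do not explain why the step occurs.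

As far as these compounds go, it remains open how the step would look with bromine atoms or methyl groups in place of the chlorines. From the compounds shown here alone, whether it holds on any further core also remains open.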